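From Propargylsulfanyl to Propylsulfanyl in an MTT Cell Series

The source may hold more compounds than are shown below. What is called first, only, known or untested is meant among the compounds shown, and "the series" means these compounds.

Measured in a functional assay on MCF7 cells (Homo sapiens) for inhibition, read by MTT assay, with a stated time of 72 h; a lower number here means a stronger inhibitor, a higher number a weaker inhibitor:
- compound 1 `Cc1cc(Nc2cc(-c3ccccc3)[nH]n2)n2nc(SCCc3ccccc3)nc2n1`: 2700 nM
- compound 2 `Cc1cc(Nc2cc(-c3ccccc3)[nH]n2)n2nc(SCC(=O)c3ccccc3)nc2n1`: 5240 nM
- compound 3 `C#CCSc1nc2nc(C)cc(Nc3cc(-c4ccccc4)[nH]n3)n2n1`: 21800 nM

Compound 3 has the highest number of the three and is the weakest inhibitor in this small set. Compound 4 `CCCSc1nc2nc(C)cc(Nc3cc(-c4ccccc4)[nH]n3)n2n1` has not yet been measured. It differs from compound 3 in one place: ethyl in place of ethynyl on a saturated chain carbon bound to a sulfur. In words, this is ethyl in place of ethynyl on a saturated chain carbon bound to a sulfur, or propargyl to propyl.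

Two measured steps involve the ethynyl group: an 8.1-fold higher number from compound 1 to compound 3 (0.91 log units; beyond the scatter) and a 4.2-fold higher number from compound 2 to compound 3 (0.62 log units; beyond the scatter). Both are modest, and both exchange it for benzyl or benzoyl, not for ethyl. The exchange between those two groups, a 1.9-fold higher number from compound 1 to compound 2 (0.29 log units; within the scatter), stays within the scatter. Within the data shown here, no measured compound carries ethyl at this place, so the data give only weak guidance on direction. In this assay, the expected result is a 1.4-fold lower number from compound 3 to compound 4 (0.13 log units; within the scatter), a small move towards a lower number that is not expected to exceed the scatter. For compound 4 the estimated value is 16000 nM, with an expected range of 7000 nM to 36000 nM.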

Compound 4, half-maximal inhibitory concentration: > 50000 nM
Compound 4: no number, only a limit; the forecaster's own chance of this, stated with the estimate: 8%; at least 3.1-fold (0.49 log units) between middle value and limit.
By their numbers in this assay, from the lowest: compounds 1 and 2 (each within the scatter of the next); then compound 3. At a limit, above all of these: compound 4.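

In this assay, among these compounds, compound 4 gives no number but only a limit, > 50000 nM, the one value in this set that sits at it: the limit of > 50000 nM in this assay, at which 1 of the 4 values shown sits. Among the compounds shown here, this position therefore responds even to a change that leaves the size of the group, as counted, untouched: ethyl and ethynyl each hold 2 heavy atoms, and the loss of the triple bond alone gives an at least 2.2-fold higher number from compound 3 to compound 4 (0.36 log units; beyond the scatter), whereas the earlier compounds only showed exchanges among ethynyl, benzyl and benzoyl. Every measured sulfanyl chain now gives a lower number than propylsulfanyl, and the steps from the two compounds with a phenyl ring in that chain are clear, with an at least 9.5-fold higher number from compound 2 to compound 4 (0.97 log units; beyond the scatter) and, large, an at least 18-fold higher number from compound 1 to compound 4 (1.26 log units; beyond the scatter).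

As far as these compounds go, since compound 4 has only a limit, the true size of these three steps stays unknown, and each could be larger than printed. The compounds shown also leave open whether a butyl chain, an amine or a carboxylic acid on a saturated chain carbon bound to a sulfur would bring the number back down in this assay.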